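A step from a fused bicyclic amide to a methoxyphenyl amide

A few compounds are considered here, and "the series" means these few. Any claim that something is new, unique, unknown or untested is made for them only; others in the source may bear on it.

Compound 1 `O=C(Nc1ccc2[nH]ncc2n1)[C@H]1CCCN1C(=O)C1(c2cccc(Cl)c2)CCCC1`: 0.159 nM
Compound 2 `O=C(Nc1ccc2[nH]c(=O)[nH]c2c1)[C@H]1CCCN1C(=O)C1(c2cccc(Cl)c2)CCCC1`: 0.398 nM

For the measured compounds named here, in an assay on isolated protein for inhibition of histone acetyltransferase p300 (Homo sapiens), with a stated time of 60 min (a lower number here means a stronger inhibitor, a higher number a weaker inhibitor), compound 2 stands highest of the two measured numbers, with a 2.5-fold higher number from compound 1 to compound 2 (0.40 log units; beyond the scatter) as its only neighbour. Compound 3 `COc1ccc(NC(=O)[C@H]2CCCN2C(=O)C2(c3cccc(Cl)c3)CCCC2)cc1` differs from compound 2 by a group of 8 heavy atoms (7 carbon, 1 oxygen; one six-membered aromatic ring of carbon only) in place of a group of 10 heavy atoms (7 carbon, 2 nitrogen, 1 oxygen; one five-membered aromatic ring with 2 hetero atoms, one six-membered aromatic ring of carbon only), on an amide-type nitrogen. Going by the values given here, only the step from compound 1 to compound 2 bears on this change, and it was modest; the move to compound 3 goes further, giving up the five-membered ring and both hydrogen-bond donors. Compound 3 is therefore expected to give a higher number in this assay, a 10-fold higher number from compound 2 to compound 3 (1.00 log units; beyond the scatter), with an estimate of 4 nM (range 0.8 nM to 20 nM).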

Compound 3, half-maximal inhibitory concentration: 100 nM
Compound 3: middle estimate off by 25-fold (1.40 log units), on the low side; measured number outside the range, above it.
By their numbers in this assay, from the lowest: compound 1; then compound 2; then compound 3.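

In this assay, this amide-type nitrogen proves far more sensitive to its substituent than the modest step between the two fused groups suggested: placing 4-methoxyphenyl there gives a 250-fold higher number from compound 2 to compound 3 (2.40 log units; beyond the scatter) and a 630-fold higher number from compound 1 to compound 3 (2.80 log units; beyond the scatter). Both fused groups thus give much lower numbers than the single-ring 4-methoxyphenyl. No available evidence accounts for this loss.

The change removes the five-membered ring and the hydrogen-bond donors together, so the compounds shown do not separate their contributions. A 4-hydroxyphenyl group on the same nitrogen would help to separate them.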